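Hydroxy in Place of Fluoro on a Core with a Low Number in This Assay

A few compounds are considered here, and "the series" means these few. Any claim that something is new, unique, unknown or untested is made for them only; others in the source may bear on it.

Compound 1 `OC[C@@]1(c2ccc(F)cc2)NC[C@@H](O)[C@@H]1O`: 0% in an assay on isolated protein for inhibition of tissue alpha-L-fucosidase (Bos taurus), tested at 1000 uM; on this read-out lower numbers stand for less inhibition and higher numbers for more inhibition at the one concentration tested (going by the name of the read-out)
Compound 2 `OC[C@]1(c2ccc(F)cc2)NC[C@H](O)[C@H]1O`: 0%
Compound 3 `OC[C@@]1(c2c(F)c(F)c(F)c(F)c2F)NC[C@@H](O)[C@@H]1O`: 3.8%

Compound 1 stands level with compound 2, the two together giving the lowest numbers of the three, while compound 3 gives a number only slightly higher, within the scatter. Among the measured compounds shown here, the single measured step, no change at the digits printed from compound 1 to compound 2 (within the scatter), rests on the fact that compounds 1 and 2 differ only in the configuration as drawn and shows nothing beyond the scatter. Compound 4 `OC[C@@]1(c2ccc(O)cc2)NC[C@@H](O)[C@@H]1O` differs from compound 1 by hydroxy in place of fluoro on an aromatic carbon. For the measured compounds named here, no measured step tests this kind of exchange, and the one step that exists was flat. The step from compound 1 to compound 4 is therefore expected to be a number 3 percentage points higher from compound 1 to compound 4 (within the scatter), with no change beyond the scatter. Compound 4 is estimated at 3%, in a range of 0% to 15%.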

Compound 4, a percentage reported as inhibition, at one concentration (the size of the read-out at that concentration, not a potency): 0%
For compound 4 the middle estimate is 3 percentage points above the measured one; the range from low to high includes it.
By their numbers in this assay, from the lowest: compounds 1, 2, 4 and 3 (each within the scatter of the next).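

In this assay hydroxy in place of fluoro on an aromatic carbon gives no change at the digits printed from compound 1 to compound 4 (within the scatter) at this position. The earlier compounds shown here did not touch this group in a single exchange, and here a hydroxy, which brings a hydrogen-bond donor and acceptor that fluoro lacks, leaves the number within the scatter. Nothing shown gives a reason for this flat step.

Going by these compounds, whether an amine, a carboxylic acid or a longer chain on this aromatic carbon would give a different number stays open. So does whether the same exchange would matter on the mirror-image core of compound 2.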